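Ethoxycarbonyl to methoxycarbonyl: working notes on compound 3

The compounds below may be only part of what the source reports. "The series", "measured", "known", "first", "only" and "open" are said of these compounds alone.

Of the compounds shown here, two have been measured so far. In a functional assay on SW1573 cells (Homo sapiens) for antiproliferative activity, read by sulforhodamine B assay, with a stated time of 48 h (on this read-out lower numbers stand for stronger inhibition of growth and higher numbers for weaker inhibition of growth), compound 1 (`CCOC(=O)C#CC(O/C=C/C(=O)OCC)C(C)C`) gives 2800 nM. In the same this assay, compound 2 (`CCCCCCC(C#CC(=O)OC)O/C=C/C(=O)OC`) gives 3300 nM. These two values lie within the usual scatter of each other, so compound 1 stands level with compound 2 and cannot be separated from it on these numbers.

The next compound to be read is compound 3 (`CCOC(=O)C#CC(O/C=C/C(=O)OC)C(C)C`), which departs from compound 1 at a single place: hydrogen in place of methyl on a saturated chain carbon bound to an oxygen next to a carbonyl group. In words, this is hydrogen in place of methyl on a saturated chain carbon bound to an oxygen next to a carbonyl group, or one ethoxycarbonyl becoming methoxycarbonyl.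

Among the measured compounds shown here, no measured pair isolates this change, so the expectation rests on little data. No step beyond the scatter is expected in this assay, and the estimated 1.1-fold higher number from compound 1 to compound 3 (0.03 log units; within the scatter) is correspondingly small. The expected value for compound 3 is 3000 nM, with an estimated range of 1500 nM to 6000 nM.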

Compound 3, concentration for 50% growth inhibition: 960 nM
For compound 3 the middle estimate is 3.1-fold (0.49 log units) above the measured one; the whole stated range lies above it.
By their numbers in this assay, from the lowest: compound 3; then compounds 1 and 2 (each within the scatter of the next).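

In this assay the change gives a 2.9-fold lower number from compound 1 to compound 3 (0.46 log units; beyond the scatter) and so marks this position as one that responds to a very small edit: one methyl leaves, one carbon in heavy atoms, with no ring, no charge and no hydrogen-bond donor or acceptor involved. The level reading of compound 1 and compound 2 could not show this, since those two differ in more than one place, whereas here the methoxycarbonyl of compound 3 goes with stronger inhibition of growth than the ethoxycarbonyl it replaces in compound 1, while the other ethoxycarbonyl stays in both. This rests on a single pair, and nothing available on these compounds accounts for the size or direction of the step.

Open, from the compounds shown here alone, is whether the same edit at the remaining ethoxycarbonyl of compound 3 would give a step of its own, in either direction. Also open, going by these compounds, is how this position reads with a longer chain such as propyl, or with a carboxylic acid or a primary amide in place of the ester, which would show whether the step belongs to the ethyl-to-methyl change alone.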